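The source may hold more compounds than are shown below. What is called first, only, known or untested is meant among the compounds shown, and "the series" means these compounds.

For the measured compounds named here, in a toxicity assay on Huh-7.5 cells (Homo sapiens) for inhibition, read by MTT assay, with a stated time of 96 h (on this read-out higher numbers stand for lower toxicity in this test and lower numbers for higher toxicity in this test), compound 1 `CC(C)Oc1ccc(C(=O)Nc2ccc(N(C)C)cc2)cc1NC(=O)C(C)Br` gives 7900 nM, and compound 2 `CC(C)Oc1ccc(C(=O)Nc2ccc(N(C)C)cc2)cc1[N+](=O)[O-]` gives 50000 nM, the higher of the two numbers so far. Compound 3 `CC(C)Oc1ccc(C(=O)Nc2ccc(N(C)C)cc2)cc1N` has not yet been measured. It differs from compound 2 by amino in place of nitro on an aromatic carbon, ortho to an isopropoxy group: amino in place of nitro on an aromatic carbon. Going by the values given here, only one measured step touches this place, a 6.3-fold higher number from compound 1 to compound 2 (0.80 log units; beyond the scatter). This modest step, beyond the scatter, replaced ((1-bromoethyl)carbonyl)amino with nitro, and it offers only indirect guidance, since compound 3 carries neither group. A small move towards a lower number in this assay is therefore expected, smaller than that measured step and perhaps not clear of the scatter. The expected change is a 1.7-fold lower number from compound 2 to compound 3 (0.22 log units; within the scatter). For compound 3 the estimated value is 30000 nM, with an expected range from 10000 nM to 80000 nM.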

Compound 3, half-maximal cytotoxic concentration: 72100 nM
The estimate for compound 3 lay 2.4-fold (0.38 log units) below the measured number, and the stated range covers the measured number.
By their numbers in this assay, from the lowest: compound 1; then compounds 2 and 3 (each within the scatter of the next).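

In this assay, amino in place of nitro on this aromatic carbon, ortho to an isopropoxy group, gives a 1.4-fold higher number from compound 2 to compound 3 (0.16 log units; within the scatter) and so does not separate the two groups at this position. Hydrogen in place of (1-bromoethyl)carbonyl on the nitrogen gives a 9.1-fold higher number from compound 1 to compound 3 (0.96 log units; beyond the scatter) and, among these three compounds, ties the lower number of compound 1 to that acyl group and not to the nitrogen alone. No evidence is available on the reason for either step.

The compounds shown leave open whether the bromine is needed for this difference, which an acetyl group on the same nitrogen would test. They also leave open whether a carboxylic acid or a nitrile on this aromatic carbon would stay level with compound 2 and compound 3 or fall towards compound 1.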